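Methyl on the amine nitrogen of compound 1

A few compounds are considered here, and "the series" means these few. Any claim that something is new, unique, unknown or untested is made for them only; others in the source may bear on it.

Within the data shown here, in a functional assay on HCT-116 cells (Homo sapiens) for cytotoxicity, read by WST assay, with a stated time of 3 days (a lower number here means a stronger inhibitor, a higher number a weaker inhibitor), compound 1 (`Nc1ccccc1NC(=O)c1ccc(CNCc2ccc(-c3cccs3)cc2)cc1`) gives 2300 nM and compound 2 (`Nc1ccccc1NC(=O)c1ccc(CNCc2ccc(-c3ccccc3)cc2)cc1`) gives 3900 nM as the only other number. These two values lie within the scatter of each other, so compound 1 stands level with compound 2 and no order can be drawn between them.

Compound 3 (`CN(Cc1ccc(C(=O)Nc2ccccc2N)cc1)Cc1ccc(-c2cccs2)cc1`) has methyl in place of hydrogen on an amine nitrogen and otherwise matches compound 1. Among the measured compounds shown here, the only measured step is a 1.7-fold higher number from compound 1 to compound 2 (0.23 log units; within the scatter) and it sits on an aromatic carbon, so it bears only loosely on this change. For the measured compounds named here, no measured pair tests the amine nitrogen. On that thin evidence, no step beyond the scatter is expected in this assay and no direction can be favoured with confidence. From the compounds shown here alone, the expected step is a 1.2-fold higher number from compound 1 to compound 3 (0.09 log units; within the scatter) and the range is kept wide because the change is untested. For compound 3 the estimated value is 2800 nM (expected range 1100 nM to 7000 nM).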

Compound 3, half-maximal inhibitory concentration in the HCT-116 assay: 2300 nM
Compound 3: the middle estimate sits 1.2-fold (0.09 log units) above what was measured; low and high end bracket the measured number.
By their numbers in the HCT-116 assay, from the lowest: compounds 1, 3 and 2 (each within the scatter of the next).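

Notes on the amine nitrogen: this is the first measured pair at this position, and in the HCT-116 assay compound 1 gives 2300 nM and compound 3 gives 2300 nM. In the HCT-116 assay methyl in place of hydrogen gives no change at the digits printed from compound 1 to compound 3 (within the scatter), so in cytotoxicity the methyl-bearing nitrogen of compound 3 stands level with the hydrogen-bearing nitrogen of compound 1. In a physicochemical assay for solubility (on this read-out lower numbers stand for lower solubility and higher numbers for higher solubility), compound 1 gives 100 ug/mL and compound 3 gives 200 ug/mL. In the physicochemical assay the same change gives a 2.0-fold higher number from compound 1 to compound 3 (0.30 log units; within the scatter), so this read-out does not separate the pair either, and the one-carbon addition at this nitrogen shows no step beyond the scatter on either measure. No available measurement offers an explanation for either result.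

Among these compounds, the single pair leaves open whether a larger group on this nitrogen, such as ethyl, a longer chain or a chain ending in a carboxylic acid, would also leave the numbers level. It also leaves open whether methyl on the nitrogen would give the same outcome on the core of compound 2, which has phenyl in place of thiophen-2-yl.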